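Adding trifluoromethyl to compound 2

A few compounds are considered here, and "the series" means these few. Any claim that something is new, unique, unknown or untested is made for them only; others in the source may bear on it.

In a functional assay on MGC-803 cells (Homo sapiens) for cytotoxicity, read by MTT assay, with a stated time of 48 h (on this read-out higher numbers stand for weaker inhibition and lower numbers for stronger inhibition), compound 2 (`O=C(CSc1ccc(Br)cc1)N1N=C(c2cc3ccccc3oc2=O)C[C@@H]1c1ccccc1`) gives 16800 nM, within the scatter of compound 1 (`O=C(CSc1ccc(Br)cc1)N1N=C(c2cc3ccccc3oc2=O)C[C@@H]1c1ccccc1C(F)(F)F`), which gives 21300 nM. Compound 3 (`O=C(CSc1ccc(Br)cc1)N1N=C(c2cc3ccccc3oc2=O)C[C@@H]1c1ccc(C(F)(F)F)cc1`) differs from compound 2 by trifluoromethyl in place of hydrogen on an aromatic carbon, with trifluoromethyl in place of hydrogen on an aromatic carbon, para to a large group. For the measured compounds named here, the only measured step bearing on this, a 1.3-fold lower number from compound 1 to compound 2 (0.10 log units; within the scatter), exchanges the same two groups at a different aromatic carbon. No step beyond the scatter is therefore expected in this assay. The expected size is a 1.1-fold higher number from compound 2 to compound 3 (0.03 log units; within the scatter). For compound 3 the estimated value is 18000 nM, with an expected range of 8000 nM to 40000 nM.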

Compound 3, half-maximal inhibitory concentration: 10800 nM
For compound 3 the middle estimate is 1.7-fold (0.22 log units) above the measured one, within the range that was stated.
By their numbers in this assay, from the lowest: compounds 3, 2 and 1 (each within the scatter of the next).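

In this assay the new place, para to a large group, gives a 1.6-fold lower number from compound 2 to compound 3 (0.19 log units; within the scatter) on entry of trifluoromethyl, so this second placement of the group also brings no step beyond the scatter. Set directly against each other, the two placements give a 2.0-fold lower number from compound 1 to compound 3 (0.29 log units; within the scatter) and so do not separate either, which leaves all three compounds unresolved on this read-out.

As far as these compounds go, whether an amine, a carboxylic acid or a longer chain at this place would give a step beyond the scatter stays open. Nothing at hand offers an explanation for these values.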